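This account rests on a few compounds, and the source may have more. Where it says the series, first, only, none or still open, it means among the compounds named here.

Compound 1 `O=C(COc1ccc2cc(/C=C3/SC(=O)NC3=O)ccc2c1)Nc1ccccn1`: in an assay on isolated protein for inhibition of histone deacetylase 8 (Homo sapiens), with a stated time of 1 h (on this read-out higher numbers stand for weaker inhibition and lower numbers for stronger inhibition), compound 1 gives only a limit, > 50000 nM.
Compound 2 `Cc1cccc2sc(NC(=O)COc3ccc4cc(/C=C5/SC(=O)NC5=O)ccc4c3)nc12`: in this assay compound 2 gives 5800 nM.

Compound 2 thus holds the only number shown, the other value being a limit (the limit of > 50000 nM in this assay, at which 1 of the 2 values shown sits). Compound 3 `O=C(COc1ccc2cc(/C=C3/SC(=O)NC3=O)ccc2c1)Nc1cccc(Cl)c1` carries 3-chlorophenyl in place of 4-methyl-1,3-benzothiazol-2-yl on an amide-type nitrogen. Going by the values given here, the single measured step at this position, an at least 8.6-fold lower number from compound 1 to compound 2 (0.93 log units; beyond the scatter), exchanged one aryl group for another on the same amide-type nitrogen, and only the 4-methyl-1,3-benzothiazol-2-yl compound reached a number. Returning to a smaller aryl, here 3-chlorophenyl, is expected to weaken inhibition: compound 3 is estimated at 20000 nM, between 5000 nM and 60000 nM, an expected step of a 3.4-fold higher number from compound 2 to compound 3 (0.54 log units; beyond the scatter) in this assay.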

Compound 3, half-maximal inhibitory concentration: > 50000 nM
Compound 3 gave a limit, no number; the forecaster's own chance of this, stated with the estimate: 40%; middle value at least 2.5-fold (0.39 log units) away from the limit.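

Replacing 4-methyl-1,3-benzothiazol-2-yl with 3-chlorophenyl gives an at least 8.6-fold higher number from compound 2 to compound 3 (0.93 log units; beyond the scatter) in this assay, so a carbon-only aryl ring on this amide-type nitrogen, like pyridin-2-yl, yields only a limit. Among the three compounds, only compound 2 gives a number, and none goes against this: the limit of > 50000 nM in this assay, at which 2 of the 3 values shown sit. The step between compound 1 and compound 3 cannot be read, as both values are limits.

As far as these compounds go, it remains open whether an unsubstituted 1,3-benzothiazol-2-yl would still give a number. The same question stands for a single-ring 1,3-thiazol-2-yl.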